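A Butanoate Ester Replaces Methylsulfonyl on the Shared Core

The source may hold more compounds than are shown below. What is called first, only, known or untested is meant among the compounds shown, and "the series" means these compounds.

Of the compounds shown here, three sharing one core have been measured in a functional assay on the whole organism with Rattus norvegicus as the target, with a stated time of 4 h, at a dose of 40 mg/kg by the intraperitoneal route; on this read-out lower numbers stand for less inhibition and higher numbers for more inhibition at the one dose given (going by the name of the read-out). Compound 1 `Cc1nc2c(OCc3ccccc3)cccn2c1CCC#N` gives 40%. Compound 2 `Cc1nc2c(OCc3ccccc3)cccn2c1CO` gives 99%. Compound 3 `Cc1nc2c(OCc3ccccc3)cccn2c1CS(C)(=O)=O` gives 61%, which places compound 3 second highest of the three values: it stands a number 21 percentage points higher from compound 1 to compound 3 (beyond the scatter) and a number 38 percentage points lower from compound 2 to compound 3 (beyond the scatter). The remaining step, a number 59 percentage points higher from compound 1 to compound 2 (beyond the scatter), shows that every change so far has been made on a saturated chain carbon bound to an aromatic carbon, and that the number there moves widely with the group carried.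

Compound 4 `CCCCC(=O)OCc1c(C)nc2c(OCc3ccccc3)cccn12` continues this series at the same place. Compared with compound 3, the difference is (butylcarbonyl)oxy in place of methylsulfonyl on a saturated chain carbon bound to an aromatic carbon. Among the measured compounds shown here, the steps that bear on it are the exchange from compound 2 to compound 3, which was large and downward, and the one from compound 1 to compound 3, which was modest and upward; neither involves the (butylcarbonyl)oxy group itself, so no direct precedent exists. Because compound 2 gave 99% and compound 3 gave 61%, compound 4 is expected to sit between them, with an estimated step of a number 19 percentage points higher from compound 3 to compound 4 (beyond the scatter) in this assay upward. The estimate for compound 4 is 80%, within a range from 50% to 99%.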

Compound 4, a percentage reported as inhibition, in the whole organism at one dose (the size of the read-out at that dose, not a potency): 45%
Compound 4: middle estimate off by 35 percentage points, on the high side; measured number below the stated range.
By their numbers in this assay, from the lowest: compounds 1 and 4 (each within the scatter of the next); then compound 3; then compound 2.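

In this assay, putting butylcarbonyl on the oxygen of compound 2 gives a number 54 percentage points lower from compound 2 to compound 4 (beyond the scatter) and so shows that keeping an oxygen on this saturated chain carbon does not by itself keep the number of compound 2, which stands at 99% and remains alone at the top of the four compounds. The (butylcarbonyl)oxy group also gives a number 16 percentage points lower from compound 3 to compound 4 (beyond the scatter) when it takes the place of methylsulfonyl, while its exchange for cyanomethyl gives a number 5 percentage points higher from compound 1 to compound 4 (within the scatter) and leaves compound 1 and compound 4 indistinguishable in this assay despite their different groups. The data shown hold no measurement that offers a reason for these differences.

The compounds shown leave open whether a shorter acyl group such as acetyl would give a number nearer that of compound 2 or that of compound 4, and how a methyl ether or an amine would read on the same carbon. They also leave open whether the order of these four compounds would hold at another dose or time, as each stands here at only one of each.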